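The source may report more compounds than this note shows. Statements on the series, on what has been measured and on what is new or still open speak of the compounds shown alone.

Measured so far in a functional assay on A549 cells (Homo sapiens) for inhibition, read by sulforhodamine B assay, with a stated time of 48 h; on this read-out higher numbers stand for weaker inhibition of growth and lower numbers for stronger inhibition of growth:

compound 1 `COc1ccc2c(c1)NC(=O)CN2c1nc(NCCCO)nc2ccccc12`: 5.18 nM
compound 2 `COc1ccc2c(c1)NC(=O)CN2c1nc(COCCCC(=O)NO)nc2ccccc12`: 550 nM
compound 3 `COc1ccc2c(c1)NC(=O)CN2c1nc(NCc2ccncc2)nc2ccccc12`: 6.62 nM

Compound 2 stands highest of the three numbers in this assay; the nearest is an 83-fold lower number from compound 2 to compound 3 (1.92 log units; beyond the scatter) and the furthest is a 110-fold higher number from compound 1 to compound 2 (2.03 log units; beyond the scatter), both beyond the scatter. Compounds 1 and 3 lie within the scatter of each other, as a 1.3-fold higher number from compound 1 to compound 3 (0.11 log units; within the scatter) shows, so no order is claimed for that pair.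

Compound 4 `CCOc1nc(N2CC(=O)Nc3cc(OC)ccc32)c2ccccc2n1` has not been measured in this assay. Its change from compound 2 is ethoxy in place of (3-(hydroxycarbamoyl)propoxy)methyl on an aromatic carbon. Both large steps from compound 2 bear on this: each removed the (3-(hydroxycarbamoyl)propoxy)methyl group from the same aromatic carbon and each gave a large fall in number. In both of those cases, though, the entering group was an amino-linked one, (3-hydroxypropyl)amino or ((pyridin-4-yl)methyl)amino, whereas ethoxy enters here with 0 hydrogen-bond donors and 1 hydrogen-bond acceptor. A step toward a lower number, well beyond the scatter, is therefore expected, but whether it reaches the level of compounds 1 and 3 is open.

For compound 4 the expected value in this assay is 30 nM, within 5 nM to 200 nM. The step this estimate implies for compound 4 is an 18-fold lower number from compound 2 to compound 4 (1.26 log units; beyond the scatter).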

Compound 4, concentration for 50% growth inhibition: 16.7 nM
Compound 4: the middle estimate sits 1.8-fold (0.25 log units) above what was measured; low and high end bracket the measured number.
By their numbers in this assay, from the lowest: compounds 1 and 3 (each within the scatter of the next); then compound 4; then compound 2.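

In this assay, the position on the aromatic carbon between two ring nitrogen atoms does not need an amino-linked group for a large fall in number: a 33-fold lower number from compound 2 to compound 4 (1.52 log units; beyond the scatter), with ethoxy entering with 0 hydrogen-bond donors and no nitrogen. Ethoxy does not fully match the two amino-linked groups, however, as both a 2.5-fold higher number from compound 3 to compound 4 (0.40 log units; beyond the scatter) and a 3.2-fold higher number from compound 1 to compound 4 (0.51 log units; beyond the scatter) are modest steps that lie beyond the scatter. Nothing available here explains either the large step or the modest ones.

Ethylamino would help show whether the modest gap follows the oxygen or nitrogen link itself or the rest of the group, while methoxy and butoxy at the same carbon would show how the number responds to the length of the alkoxy chain. On these data alone, it also remains open whether the high number of compound 2 follows the hydroxycarbamoyl end or the chain that carries it, which a carboxylic acid or a plain methyl end on that chain would help separate.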